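The compounds below may be only part of what the source reports. "The series", "measured", "known", "first", "only" and "open" are said of these compounds alone.

Notes on the series. Two ureas built on the shared core have been run in a functional assay on HUVEC cells (Homo sapiens) for antiproliferative activity, read by MTT assay, with a stated time of 48 h; a lower number here means a stronger inhibitor, a higher number a weaker inhibitor. Compound 1 `O=C(Nc1ccccc1)Nc1nnc(Sc2ncnc3scc(-c4ccncc4)c23)s1` gives 19300 nM in this assay. Compound 2 `Cc1ccc(NC(=O)Nc2nnc(Sc3ncnc4scc(-c5ccncc5)c34)s2)cc1Cl` gives 23200 nM in this assay. Among the compounds with values here, the only step between measured compounds, a 1.2-fold higher number from compound 1 to compound 2 (0.08 log units; within the scatter), lies within the scatter, so the two numbers cannot be ordered. On the numbers shown, compound 2 stands next to compound 1 at a separation that the scatter covers; no placement of one before the other can be read from that pair.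

Compound 3 `COc1ccc(NC(=O)Nc2nnc(Sc3ncnc4scc(-c5ccncc5)c34)s2)cc1` is the next member. The change from compound 2 is 4-methoxyphenyl in place of 3-chloro-4-methylphenyl on an amide-type nitrogen. Within the data shown here, the one measured step at this position, a 1.2-fold higher number from compound 1 to compound 2 (0.08 log units; within the scatter), exchanged one aryl group for another without movement beyond the scatter. Nothing measured in the series separates a methoxy-bearing aryl from the others. The expectation for this assay is therefore a step no larger than the scatter and without a preferred direction, expected as a 1.2-fold lower number from compound 2 to compound 3 (0.06 log units; within the scatter). For compound 3 the estimate in this assay is 20000 nM, expected to fall between 8000 nM and 50000 nM.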

Compound 3, half-maximal inhibitory concentration: 16900 nM
The estimate for compound 3 lay 1.2-fold (0.07 log units) above the measured number; the range from low to high includes it.
By their numbers in this assay, from the lowest: compounds 3, 1 and 2 (each within the scatter of the next).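

In this assay, the step from a chloro- and methyl-bearing aryl group to 4-methoxyphenyl on the amide-type nitrogen is a 1.4-fold lower number from compound 2 to compound 3 (0.14 log units; within the scatter), and methoxy in place of hydrogen on an aromatic carbon is a 1.1-fold lower number from compound 1 to compound 3 (0.06 log units; within the scatter). The earlier pair showed one aryl exchange within the scatter; these three compounds now show that phenyl, 3-chloro-4-methylphenyl and 4-methoxyphenyl cannot be separated at this nitrogen, even though 4-methoxyphenyl brings a hydrogen-bond acceptor that the other two lack and replaces chlorine with oxygen. No supporting data bear on why the three numbers remain this close.

On these data alone, all three ureas carry a single substituted or unsubstituted phenyl group on this nitrogen, so it remains open whether a carboxylic acid or a dimethylamino group on that ring, or a cyclohexyl group or longer alkyl chain in place of the ring, would give a step beyond the scatter. The shared core is also unchanged across these compounds, leaving open how far the number depends on the urea substituent rather than on the core.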